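This account rests on a few compounds, and the source may have more. Where it says the series, first, only, none or still open, it means among the compounds named here.

Measured in a functional assay on B16-F0 cells (Mus musculus) for inhibition, read by CCK-8 assay, with a stated time of 48 h; on this read-out lower numbers stand for stronger inhibition and higher numbers for weaker inhibition:
- compound 1 `COc1cc(-c2ccnc3cc(-c4ccc(Cl)cc4)nn23)cc(OC)c1OC`: 4090 nM
- compound 2 `COc1cc(-c2ccnc3cc(-c4ccc(N(C)C)cc4)nn23)cc(OC)c1OC`: 702 nM
- compound 3 `COc1cc(-c2ccnc3cc(-c4ccc5ccn(C)c5c4)nn23)cc(OC)c1OC`: 657 nM

The low end of these three numbers is shared, since the data show a 1.1-fold lower number from compound 2 to compound 3 (0.03 log units; within the scatter), a step within the scatter. The gap to the 4-chlorophenyl member is larger, at a 6.2-fold lower number from compound 1 to compound 3 (0.79 log units; beyond the scatter), and lies beyond the scatter.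

The next compound is compound 4 `COc1ccc(-c2cc3nccc(-c4cc(OC)c(OC)c(OC)c4)n3n2)cc1`. It carries 4-methoxyphenyl in place of 1-methyl-1H-indol-6-yl on an aromatic carbon of a five-membered aromatic ring with 2 nitrogen (4-methoxyphenyl in place of 1-methyl-1H-indol-6-yl on an aromatic carbon). Among the measured compounds shown here, no measured compound carries this group, so the nearest guides are the two other para-free comparisons the series offers: the 4-chlorophenyl and 4-(dimethylamino)phenyl groups. Exchanging chloro for dimethylamino gave a 5.8-fold lower number from compound 1 to compound 2 (0.77 log units; beyond the scatter), a modest step, so the group on this phenyl ring can move the number beyond the scatter. The value of compound 1 and the value of compound 3 therefore frame the expectation, and a small rise towards the former seems most likely in this assay. The expected step is a 1.8-fold higher number from compound 3 to compound 4 (0.26 log units; within the scatter), not clearly beyond the scatter. For compound 4 the estimated value is 1200 nM, with an expected range from 400 nM to 3500 nM.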

Compound 4, half-maximal inhibitory concentration: 1410 nM
Compound 4: middle estimate off by 1.2-fold (0.07 log units), on the low side; the measured number falls inside the stated range.
By their numbers in this assay, from the lowest: compounds 3, 2 and 4 (each within the scatter of the next, the first and the last beyond it); then compound 1.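

In this assay, 4-methoxyphenyl in place of 1-methyl-1H-indol-6-yl on this aromatic carbon gives a 2.1-fold higher number from compound 3 to compound 4 (0.33 log units; beyond the scatter), a modest step beyond the scatter, so the exchange of these two groups can be told apart here, unlike the earlier exchange of the same 1-methyl-1H-indol-6-yl for 4-(dimethylamino)phenyl. Within the phenyl groups, methoxy in place of chloro gives a 2.9-fold lower number from compound 1 to compound 4 (0.46 log units; beyond the scatter), also beyond the scatter, whereas methoxy in place of dimethylamino gives a 2.0-fold higher number from compound 2 to compound 4 (0.30 log units; within the scatter), which stays within it, so compound 4 separates from the chloro member but not from the dimethylamino member. No evidence is available on why these groups differ in this assay. The compounds shown leave open how an unsubstituted phenyl, a hydroxy group, a cyclic amine such as morpholine or a carboxylic acid on this ring would read in this assay. They also leave open whether the same differences among these groups would hold with any change elsewhere on the shared core, which stays the same in all four compounds.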